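Sulfur substituent series: isopropyl in place of 4-fluorobenzyl

A few compounds are considered here, and "the series" means these few. Any claim that something is new, unique, unknown or untested is made for them only; others in the source may bear on it.

Compound 1 `CCSc1n[nH]c(-n2[se]c3ccccc3c2=O)n1` carries an ethyl on the sulfur; in a functional assay on HeLa cells (Homo sapiens) for antiproliferative activity, read by CCK-8 assay, with a stated time of 48 h (a higher number here means a weaker inhibitor, a lower number a stronger inhibitor), compound 1 gives 14100 nM. Compound 2 `O=c1c2ccccc2[se]n1-c1nc(SCc2ccc(F)cc2)n[nH]1` carries a 4-fluorobenzyl on that sulfur instead. In this assay compound 2 gives > 50000 nM, which is a limit of the assay and not a number (the limit of > 50000 nM in this assay, at which 1 of the 2 values shown sits). Compound 2 thus stands at the weak end of the two values shown, with only a bound and no exact number. The measured step of an at least 3.5-fold higher number from compound 1 to compound 2 (0.54 log units; beyond the scatter) is the one that bears on the next change. Compound 3 `CC(C)Sc1n[nH]c(-n2[se]c3ccccc3c2=O)n1` is not yet measured; it differs from compound 2 by isopropyl in place of 4-fluorobenzyl on a sulfur. This change removes the 4-fluorobenzyl whose entry in the step of an at least 3.5-fold higher number from compound 1 to compound 2 (0.54 log units; beyond the scatter) went with a higher number, and puts in an isopropyl, a small saturated chain like the ethyl of compound 1. The expectation is therefore a step in the opposite direction, back toward the number of compound 1, of a size at least comparable to the measured one, though the limit on compound 2 leaves its exact size open. Expected is a step of an at least 3.3-fold lower number from compound 2 to compound 3 (0.52 log units; beyond the scatter). Compound 3 is estimated at 15000 nM, with a range of 6000 nM to 50000 nM.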

Compound 3, half-maximal inhibitory concentration: 34600 nM
For compound 3 the middle estimate is 2.3-fold (0.36 log units) below the measured one, and the stated range covers the measured number.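

In this assay, one added methyl on the chain at the sulfur is enough to move the number, with a 2.5-fold higher number from compound 1 to compound 3 (0.39 log units; beyond the scatter), so the weakening is not confined to the large 4-fluorobenzyl; the ethyl of compound 1 leaves compound 1 the strongest of the three, as both steps from it lie beyond the scatter. The smaller isopropyl does not clearly recover activity against the 4-fluorobenzyl, as the step shows only an at least 1.4-fold lower number from compound 2 to compound 3 (0.15 log units; that floor lies within the scatter). Compound 2 stands at a limit of the assay and not a number, so the full size of that step stays unknown: the limit of > 50000 nM in this assay, at which 1 of the 3 values shown sits.

Open, from the compounds shown here alone, is whether a straight propyl chain on the sulfur would behave like the branched isopropyl or like the ethyl, which would separate chain length from branching, and whether a methyl on the sulfur would lower the number further. Also open, going by these compounds, is how an amine or a carboxylic acid carried on the sulfur chain would read in this assay.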